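Swapping Amino for Hydroxy on Two Related Compounds

The source may report more compounds than this note shows. Statements on the series, on what has been measured and on what is new or still open speak of the compounds shown alone.

Measured compounds:
Compound 1, `Nc1ccccc1-c1ncc(C(=O)O)c(=O)[nH]1`: 50 mg/kg
Compound 2, `O=C(O)c1cnc(-c2ccccc2O)[nH]c1=O`: > 5 mg/kg
Compound 3, `CCOC(=O)c1cnc(-c2ccccc2N)[nH]c1=O`: "not determined" (no result reported)

In a functional assay on the whole organism (strain Sprague-Dawley) for inhibition, with Rattus norvegicus as the target, with a stated time of 10 min (a lower number here means that less compound is needed, a higher number that more compound is needed for the effect), compound 1 gives 50 mg/kg. Compound 2 reaches only a limit of the assay, > 5 mg/kg. The step that the limit leaves unreadable from compound 1 to compound 2 therefore has no readable size. Compound 2 sits at the limit of > 5 mg/kg in this assay, at which 1 of the 3 values shown sits. The change behind that step is hydroxy in place of amino on an aromatic carbon. In this assay compound 3 gives "not determined" (no result reported). Its core differs from the core of compound 1 by ethyl in place of hydrogen on an oxygen next to a carbonyl group. Compound 4, `CCOC(=O)c1cnc(-c2ccccc2O)[nH]c1=O`, is not yet measured; it differs from compound 3 by hydroxy in place of amino on an aromatic carbon, the same change at the same place as from compound 1 to compound 2. The earlier step gives no size and compound 3 has no number, so the expectation for compound 4 rests on compound 1 at 50 mg/kg alone. Compound 4 is expected to need about 50 mg/kg in this assay, estimated between 10 mg/kg and 300 mg/kg, with a real chance that only a limit is reported.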

Compound 4, dose for 50% inhibition: 5 mg/kg
The estimate for compound 4 lay 10-fold (1.00 log units) above the measured number; the measured number lies below the stated range.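

Whether the swap of hydroxy for amino carries from one core to another cannot be judged here, and the size of the steps that touch compound 2 cannot be read. On the core of compound 1, the swap ends in a limit, not a number: the limit of > 5 mg/kg in this assay, at which 1 of the 4 values shown sits. Ethyl in place of hydrogen on an oxygen next to a carbonyl group gives a number no higher from compound 2 to compound 4 (the limit leaves the size open). In this assay compound 4 gives 5 mg/kg, but compound 3 has no result, so this value shows only where compound 4 stands and not what the swap does on the core that carries ethyl.

On these data alone, the size of the swap on either core stays open. So does the effect of a longer chain in place of the ethyl, or of a methoxy in place of the hydroxy.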